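This account rests on a few compounds, and the source may have more. Where it says the series, first, only, none or still open, it means among the compounds named here.

Measured so far:
compound 1 `Cc1cc(N2CCCCC2)nc(SCc2nc3ccccc3[nH]2)n1`: > 100000 nM (a limit)
compound 2 `COc1ccccc1Nc1cc(C)nc(SCc2nc3ccccc3[nH]2)n1`: 70800 nM

For the measured compounds named here, in a functional assay on PC-3 cells (Homo sapiens) for cytotoxicity, read by MTT assay, with a stated time of 72 h (on this read-out higher numbers stand for weaker inhibition and lower numbers for stronger inhibition), compound 2 gives 70800 nM, the only number in the set. Compound 1 reports only a limit, (the limit of > 100000 nM in this assay, at which 1 of the 2 values shown sits). Going by the values given here, the single measured step, an at least 1.4-fold lower number from compound 1 to compound 2 (0.14 log units; that floor lies within the scatter), starts at that limit and concerns a different exchange than the one here. Compound 3 `Cc1cc(N(C)Cc2ccccc2)nc(SCc2nc3ccccc3[nH]2)n1` differs from compound 2 by benzyl(methyl)amino in place of (2-methoxyphenyl)amino on an aromatic carbon. Among the compounds with values here, no measured step bears on this change, so no shift beyond the scatter is expected. Compound 3 is estimated at 80000 nM, in a range of 30000 nM to 200000 nM. The expected step is a 1.1-fold higher number from compound 2 to compound 3 (0.05 log units; within the scatter).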

Compound 3, half-maximal inhibitory concentration: > 100000 nM
Compound 3: only a limit was reported (the forecaster's own chance of this, stated with the estimate: 40%); at least 1.2-fold (0.09 log units) between middle value and limit.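

In this assay compound 3 gives only a limit, > 100000 nM, so a second tertiary amine on this aromatic carbon next to the ring nitrogen yields no measured number. Benzyl(methyl)amino in place of (2-methoxyphenyl)amino gives an at least 1.4-fold higher number from compound 2 to compound 3 (0.14 log units; that floor lies within the scatter), so the two groups cannot be ranked. The step between compound 1 and compound 3 cannot be read, because both values are limits: the limit of > 100000 nM in this assay, at which 2 of the 3 values shown sit.

Still open, on these data alone, is whether any group on this carbon moves the number beyond the scatter. A morpholine or an unsubstituted phenylamino group would test this.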